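Chloro removal on the anilide ring of a chromone acrylamide

A few compounds are considered here, and "the series" means these few. Any claim that something is new, unique, unknown or untested is made for them only; others in the source may bear on it.

Measured compounds:
compound 1, `COc1ccc2c(=O)c(/C=C/C(=O)Nc3cccc(Cl)c3)coc2c1`, 1100000 nM
compound 2, `O=C(/C=C/c1coc2cc(O)ccc2c1=O)NCc1ccccc1`, 436000 nM

Of the compounds shown here, two from this series have been tested in an ADME assay on HepG2 2.2.15 cells (Homo sapiens) for cytotoxicity, read by MTT assay, with stated times of 48 h and 9 days; on this read-out lower numbers stand for higher toxicity in this test and higher numbers for lower toxicity in this test. Compound 1 gives 1100000 nM, the highest of the two numbers, and compound 2 gives 436000 nM; the gap between them lies beyond the usual scatter, so compound 1 is the less toxic of the pair in this assay. The two differ in more than one place, so no single change can be read from that gap.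

Compound 3, `COc1ccc2c(=O)c(/C=C/C(=O)Nc3ccccc3)coc2c1`, is the next compound to be measured in this assay. Its relation to compound 1 is a single change: hydrogen in place of chloro on an aromatic carbon. The rest of the shared core and the anilide are unchanged.

For the measured compounds named here, no step of this kind has yet been measured here, so the expectation rests on compound 1 alone, which gives 1100000 nM. The step from compound 1 to compound 3 is expected to be small, a 1.2-fold higher number from compound 1 to compound 3 (0.07 log units; within the scatter), at most a slight rise of the number and most likely within the scatter. Compound 3 is therefore estimated at 1300000 nM, with a range from 500000 nM to 3500000 nM.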

Compound 3, half-maximal cytotoxic concentration: 523000 nM
The estimate for compound 3 lay 2.5-fold (0.40 log units) above the measured number; the range from low to high includes it.
By their numbers in this assay, from the lowest: compounds 2 and 3 (each within the scatter of the next); then compound 1.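

For the compounds shown here, compound 1 and compound 3 form the first pair here that differs in one place, so a single change can now be read in this assay as the step of a 2.1-fold lower number from compound 1 to compound 3 (0.32 log units; beyond the scatter) on replacing chloro with hydrogen on an aromatic carbon of the anilide ring, meta to a large group. This shows that the chloro at this position is not silent in this test: its loss moves the number beyond the scatter, towards higher toxicity, although the step remains modest. No measurement at hand accounts for this shift.

As far as these compounds go, it remains open whether chloro matters only at this position on the ring or would give a similar step elsewhere on it, and whether the step belongs to chloro in particular or would also appear with fluoro, bromo or a methyl group in its place. From the compounds shown here alone, how an amine or a carboxylic acid at the same position would read in this assay is also open, as is whether the same step would hold on the shared core with a hydroxy group in place of the methoxy group.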